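Compound 1 to compound 4: a change of tetrazole attachment

This account rests on a few compounds, and the source may have more. Where it says the series, first, only, none or still open, it means among the compounds named here.

In an ADME assay on S9 fraction from liver (Rattus norvegicus) for metabolic stability, read by LC-MS, using NADPH, with a stated time of 30 min (a lower number here means that less of the compound is left, a higher number that more of the compound is left), compound 1 `CCCCCCCCc1ccc(OCC(=O)Cn2nnc(SC)n2)cc1` gives < 5%, which is a limit of the assay and not a number. This is the limit of < 5% in this assay, at which 1 of the 3 values shown sits. Compound 2 `CCCCCCCCc1ccc(OCC(=O)Cn2nnc(-c3ccc(C(=O)OC)cc3)n2)cc1` gives 64%, and compound 3 `CCCCCCCCc1ccc(OCC(=O)Cn2nnc(-c3cccs3)n2)cc1` gives 8%.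

Compound 4 `CCCCCCCCc1ccc(OCC(=O)Cn2nnnc2SC)cc1` has the same atoms as compound 1, joined differently: 5-(methylsulfanyl)-1H-tetrazol-1-yl in place of 5-(methylsulfanyl)-2H-tetrazol-2-yl on a saturated chain carbon bound to a carbonyl carbon. The methylsulfanyl group stays, but 5-(methylsulfanyl)-1H-tetrazol-1-yl replaces 5-(methylsulfanyl)-2H-tetrazol-2-yl.

The measured steps all exchange the group on the aromatic carbon, so they bear on this change only indirectly. The large steps are a number at least 59 percentage points higher from compound 1 to compound 2 (beyond the scatter) and a number 56 percentage points lower from compound 2 to compound 3 (beyond the scatter), and both involve the 4-(methoxycarbonyl)phenyl group, which compound 4 lacks. The remaining step, a number at least 3 percentage points higher from compound 1 to compound 3 (that floor lies within the scatter), has a floor within the scatter. Going by the values given here, no measured step covers a change of attachment, so the expectation starts from compound 1 at < 5%.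

The expected result in this assay is a number at least 5 percentage points higher from compound 1 to compound 4 (that floor lies within the scatter), with no clear direction beyond the scatter.

For compound 4 the estimate is 10%, with an expected range from 3% to 30%.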

Compound 4, percent of the compound remaining: 21%
Compound 4: the middle estimate sits 11 percentage points below what was measured; the range from low to high includes it.
By their numbers in this assay, from the lowest: compound 3; then compound 4; then compound 2. At a limit, below all of these: compound 1.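

In this assay the change of attachment on a saturated chain carbon bound to a carbonyl carbon gives a number at least 16 percentage points higher from compound 1 to compound 4 (beyond the scatter), so how the tetrazole is joined matters at this position, even with the same atoms and the methylsulfanyl group kept. The earlier steps shown here exchanged only the group on the aromatic carbon, whereas this one shows that the read-out also responds to 5-(methylsulfanyl)-1H-tetrazol-1-yl in place of 5-(methylsulfanyl)-2H-tetrazol-2-yl. The value of compound 1 is a limit of the assay and not a number, so this step has only a floor: the limit of < 5% in this assay, at which 1 of the 4 values shown sits.

Going by these compounds, whether the same change of attachment would shift the read-out with 4-(methoxycarbonyl)phenyl or thiophen-2-yl in place of methylsulfanyl remains open. On these data alone, how an amine or a carboxylic acid at that place would read with either attachment is also open.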